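This account rests on a few compounds, and the source may have more. Where it says the series, first, only, none or still open, it means among the compounds named here.

Measured in an ADME assay on L02 cells (Homo sapiens) for antiproliferative activity, read by MTT assay, with a stated time of 72 h; a higher number here means a weaker inhibitor, a lower number a stronger inhibitor:
- compound 1 `CCN(CC)CCNC(=O)c1ccc(C(CC)(CC)c2ccc(OCC(O)C(C)(C)C)c(C)c2)n1CC`: 21200 nM
- compound 2 `CCN(CC)CCNC(=O)c1cc(C(CC)(CC)c2ccc(C#CC(O)(CC)CC)c(C)c2)cn1CC`: 42100 nM

Compound 2, at 42100 nM, lies within the scatter of compound 1, so the pair cannot be ordered. Compound 3 `CCn1cc(C(CC)(CC)c2ccc(C#CC(O)(CC)CC)c(C)c2)cc1C(=O)N[C@@H](C)CO` differs from compound 2 as follows: 1-(hydroxymethyl)ethyl in place of 2-(diethylamino)ethyl on an amide-type nitrogen. It carries 1-(hydroxymethyl)ethyl in place of 2-(diethylamino)ethyl on an amide-type nitrogen. Among the compounds with values here, no measured pair shows this change, so the expectation is loose. A modest rise in the number in this assay, towards weaker inhibition, is expected: the estimated step is a 1.4-fold higher number from compound 2 to compound 3 (0.15 log units; within the scatter). For compound 3 the estimated value is 60000 nM, with an expected range of 25000 nM to 150000 nM.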

Compound 3, half-maximal inhibitory concentration: 35400 nM
Estimate against measurement, compound 3: 1.7-fold (0.23 log units) above; low and high end bracket the measured number.
By their numbers in this assay, from the lowest: compounds 1, 3 and 2 (each within the scatter of the next).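

On the amide-type nitrogen, 1-(hydroxymethyl)ethyl in place of 2-(diethylamino)ethyl gives a 1.2-fold lower number from compound 2 to compound 3 (0.08 log units; within the scatter) in this assay and stays within the scatter. Within the data shown here, this is the first one-place comparison at this position, and it shows that the read-out does not separate these two chains, so the diethylamino end is not required for a number at this level. Nothing measured here bears on the reason for this result. Open, going by these compounds, is whether a carboxylic acid, a morpholine or a longer chain on this nitrogen would move the number beyond the scatter. Also open, on these data alone, is whether the mirror-image form of the 1-(hydroxymethyl)ethyl stereocentre would read the same.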